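Series notes: from compound 2 toward compound 4

This account rests on a few compounds, and the source may have more. Where it says the series, first, only, none or still open, it means among the compounds named here.

Measured so far in a functional assay on PANC-1 cells (Homo sapiens) for antiproliferative activity, read by MTT assay, with a stated time of 48 h; on this read-out lower numbers stand for stronger inhibition and higher numbers for weaker inhibition:
compound 1, `CC1(C)CC(=O)C2=C(C1)OC(N)=C(C#N)C2c1ccc(S(C)(=O)=O)cc1`: > 300 ug/mL, a limit of the assay
compound 2, `N#Cc1ccc(C(c2c(O)c3ccccc3oc2=O)c2c(O)c3ccccc3oc2=O)cc1`: 93.5 ug/mL
compound 3, `CC1(C)CC(=O)C2=C(C1)OC(N)=C(C#N)C2c1cc(C(F)(F)F)cc(C(F)(F)F)c1`: > 300 ug/mL, a limit of the assay

For the measured compounds named here, compound 2 holds the only number on record; the other two entries are limits, so two of the three values sit at the limit of > 300 ug/mL in this assay, at which 2 of the 3 values shown sit. Going by the values given here, no step between measured compounds that differ in one place exists, and compound 2 cannot be placed against compound 1 or compound 3 beyond what those limits show.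

Compound 4, `O=c1oc2ccccc2c(O)c1C(c1ccc(F)c(F)c1)c1c(O)c2ccccc2oc1=O`, differs from compound 2 in one place: 3,4-difluorophenyl in place of 4-cyanophenyl on a saturated chain carbon bound to two aromatic carbons. Nothing measured speaks to this exchange, so in this assay the expected step is a 1.0-fold higher number from compound 2 to compound 4 (0.01 log units; within the scatter), none beyond the usual scatter. Compound 4 is expected to give 95 ug/mL, within 45 ug/mL to 200 ug/mL.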

Compound 4, half-maximal inhibitory concentration: 82.4 ug/mL
Beside the measured number, compound 4's estimate is 1.2-fold (0.06 log units) above it, and the stated range covers the measured number.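

In this assay, for the compounds shown here, 3,4-difluorophenyl in place of 4-cyanophenyl on a saturated chain carbon bound to two aromatic carbons gives a 1.1-fold lower number from compound 2 to compound 4 (0.05 log units; within the scatter), the only step on record. At this position the two groups are not told apart, so the nitrile is not needed to keep the number within the scatter. Nothing on record speaks to the reason for so small a step.

Open, going by these compounds, is whether an amine or a carboxylic acid on the phenyl ring at this place would move the number beyond the scatter. Going by these compounds alone, no one-place step ties compound 1 or compound 3 to this pair, so those comparisons cannot be read.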